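Ethynyl to 1,1-difluoroethyl on compound 3

The compounds below may be only part of what the source reports. "The series", "measured", "known", "first", "only" and "open" are said of these compounds alone.

Compound 1 `CC(C)(C)c1conc1N1C(=O)CSC1c1cccc(C(=O)NCCCCc2ccccc2)c1` reads > 1000 nM in a functional assay on HOS-TE85 cells (Homo sapiens) for inhibition, read by CCK-8 assay, with a stated time of 72 h (a higher number here means a weaker inhibitor, a lower number a stronger inhibitor), and this value is a limit of the assay, not a number. Compound 2 `COc1cc(F)ccc1N1C(=O)CSC1c1cccc(C(=O)NCCCCc2ccccc2)c1` gives 71.1 nM. Compound 3 `C#Cc1cccc(N2C(=O)CSC2c2cccc(C(=O)NCCCCc3ccccc3)c2)c1` gives 149 nM, the higher of the two actual numbers in the series.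

Compound 4 `CC(F)(F)c1cccc(N2C(=O)CSC2c2cccc(C(=O)NCCCCc3ccccc3)c2)c1` carries one change: 1,1-difluoroethyl in place of ethynyl on an aromatic carbon.

Two steps from the limit are wide, an at least 14-fold lower number from compound 1 to compound 2 (1.14 log units; beyond the scatter) and an at least 6.7-fold lower number from compound 1 to compound 3 (0.82 log units; beyond the scatter). Each replaces the whole group on the amide-type nitrogen, including its five-membered aromatic ring, so neither is a close guide to this smaller exchange. The nearer guide is a 2.1-fold higher number from compound 2 to compound 3 (0.32 log units; beyond the scatter), a modest step between two substituted phenyl groups. Within the data shown here, no measured step isolates the ethynyl position alone, so no clear direction is expected in this assay, and the expected change is small.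

The estimated step is a 1.0-fold higher number from compound 3 to compound 4 (0.00 log units; within the scatter), with no shift expected beyond the scatter.

In this assay the estimate for compound 4 is 150 nM, with an expected range of 50 nM to 450 nM.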

Compound 4, half-maximal inhibitory concentration: 29.1 nM
Compound 4: middle estimate off by 5.2-fold (0.71 log units), on the high side, and the stated range ends above it.
By their numbers in this assay, from the lowest: compound 4; then compound 2; then compound 3. At a limit, above all of these: compound 1.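

In this assay this aromatic carbon proves sensitive to the exchange of ethynyl for 1,1-difluoroethyl, with a 5.1-fold lower number from compound 3 to compound 4 (0.71 log units; beyond the scatter), a change confined to this one group. Against the other substituted phenyl the new group also gives a lower number, with a 2.4-fold lower number from compound 2 to compound 4 (0.39 log units; beyond the scatter), and the widest gap in the series is an at least 34-fold lower number from compound 1 to compound 4 (1.53 log units; beyond the scatter). Compound 1 stands at a limit, not a number, so that last step is only a bound: the limit of > 1000 nM in this assay, at which 1 of the 4 values shown sits.

The compounds shown leave open whether trifluoromethyl, ethyl or a nitrile on this carbon would read like 1,1-difluoroethyl or like ethynyl. They also do not tell whether the fluorine atoms or the larger group account for the step, or how 1,1-difluoroethyl reads on another carbon of this ring.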